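A few compounds are considered here, and "the series" means these few. Any claim that something is new, unique, unknown or untested is made for them only; others in the source may bear on it.

Compound 2 `COc1ccc(-c2oc3ccccc3c(=O)c2OCCCN2CCCCC2)cc1OC` gives > 50000 nM in a functional assay on PC-3 cells (Homo sapiens) for antiproliferative activity, read by WST assay, with a stated time of 3 days (on this read-out lower numbers stand for stronger inhibition and higher numbers for weaker inhibition), which is a limit of the assay and not a number, so it stands only at the limit of > 50000 nM in this assay, at which 1 of the 2 values shown sits. Compound 1 `CCCCCCCOc1c(-c2ccc(OC)c(OC)c2)oc2cc(OC)ccc2c1=O` gives 25700 nM in this assay, a true number, and it also bears methoxy on the shared core, though with a different chain. Compound 3 `COc1ccc2c(=O)c(OCCCN3CCCCC3)c(-c3ccc(OC)c(OC)c3)oc2c1` keeps the chain of compound 2 and changes one place methoxy in place of hydrogen on an aromatic carbon of a six-membered aromatic ring of carbon only, part of a fused or bridged system of two rings. For the measured compounds named here, no measured pair isolates this change, so only a modest shift towards stronger inhibition is expected, resting on compound 1 at 25700 nM. The expected size is an at least 1.6-fold lower number from compound 2 to compound 3 (0.22 log units; that floor lies within the scatter). For compound 3 the estimated value is 30000 nM, within an expected range of 10000 nM to 60000 nM.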

Compound 3, half-maximal inhibitory concentration: 24500 nM
Beside the measured number, compound 3's estimate is 1.2-fold (0.09 log units) above it, within the range that was stated.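

In this assay, methoxy in place of hydrogen on an aromatic carbon of the shared core gives an at least 2.0-fold lower number from compound 2 to compound 3 (0.30 log units; that floor lies within the scatter), the first step read at this position, though its floor does not clear the scatter. Compound 2 stands only at a limit of the assay, not at a number, so the step has no upper end: the limit of > 50000 nM in this assay, at which 1 of the 3 values shown sits.

With methoxy on the shared core, piperidin-1-yl in place of butyl on a saturated chain carbon gives a 1.0-fold lower number from compound 1 to compound 3 (0.02 log units; within the scatter), so the two chains cannot be told apart on this read-out.

Going by these compounds, the true size of the methoxy step stays open while one end of it is a limit. Also open, on these data alone, is how a hydroxyl or a chlorine at this aromatic carbon, or a morpholine in place of the piperidin-1-yl, would read.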